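The source may hold more compounds than are shown below. What is called first, only, known or untested is meant among the compounds shown, and "the series" means these compounds.

Two compounds of the series have so far been run in an assay on HEK293 cells for binding affinity to Substance-K receptor (Rattus norvegicus), read by FRET, tested at 10 uM; on this read-out lower numbers stand for less inhibition and higher numbers for more inhibition at the one concentration tested (going by the name of the read-out). Compound 1 `COc1ccc(CN(CC#N)Cc2ccccc2)cc1` gives 0%. Compound 2 `CCOC(=O)CCCCN(Cc1ccccc1)Cc1ccc2ccccc2c1` gives 0%, level with compound 1 at the digits shown and within the scatter of it. Compound 3 `CCCCNC(=O)CN(Cc1ccccc1)Cc1ccc2ccccc2c1` is the next member and differs from compound 2 by butylcarbamoyl in place of 3-(ethoxycarbonyl)propyl on a saturated chain carbon bound to an amine nitrogen. Going by the values given here, no measured pair isolates this change, and both measured compounds sit at zero, so nothing in the data points to a shift beyond the scatter. The step of no change at the digits printed from compound 2 to compound 3 (within the scatter) is expected to be none beyond the scatter. Compound 3 is accordingly estimated at 0%, within -10% to 12%.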

Compound 3, a percentage reported as inhibition, at one concentration (the size of the read-out at that concentration, not a potency): 0%
The estimate for compound 3 equals the measured number at the digits printed; the range from low to high includes it.
By their numbers in this assay, from the lowest: compounds 1, 2 and 3 (each within the scatter of the next).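

Butylcarbamoyl in place of 3-(ethoxycarbonyl)propyl on a saturated chain carbon bound to an amine nitrogen gives no change at the digits printed from compound 2 to compound 3 (within the scatter) in this assay. Going by these compounds alone, this is the first comparison that isolates one place, and exchanging the ethoxycarbonyl chain for one carrying the amide hydrogen does not lift the reading off zero. No measurement bears on why these two compounds read alike.

On these data alone, whether a carboxylic acid or an amine at this place would give a reading above zero remains open. With both compounds at zero, the size of any effect of this change cannot be judged.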